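Replacing the sulfinyl benzoic acid of compound 2 with an aminophenyl thioether

The compounds below may be only part of what the source reports. "The series", "measured", "known", "first", "only" and "open" are said of these compounds alone.

Compound 2 `COc1ccc(CCCCCCCCOc2ccc(C[S+]([O-])c3cccc(C(=O)O)c3)nc2/C=C/C(=O)O)cc1` stands highest of the three numbers in a functional assay on U-937 cells (Homo sapiens) for antagonist activity, read by calcium flux (on this read-out higher numbers stand for weaker inhibition and lower numbers for stronger inhibition), giving 1100 nM; compound 1 `CCCCCCCCCCCCOc1ccc(C[S+]([O-])c2cccc(C(=O)O)c2)nc1/C=C/C(=O)O` gives 930 nM and compound 3 `COc1ccc(CCCCCCCCOc2ccc(C[S+]([O-])c3cccc(CS(=O)(=O)C(F)(F)F)c3)nc2/C=C/C(=O)O)cc1` gives 550 nM, both within the scatter of compound 2. The step of a 1.2-fold higher number from compound 1 to compound 2 (0.07 log units; within the scatter) and the step of a 2.0-fold lower number from compound 2 to compound 3 (0.30 log units; within the scatter) were each within the scatter. Compound 4 `COc1ccc(CCCCCCCCOc2ccc(CSc3cccc(N)c3)nc2/C=C/C(=O)O)cc1` differs from compound 2 by a group of 8 heavy atoms (6 carbon, 1 nitrogen, 1 sulfur; one six-membered aromatic ring of carbon only) in place of a group of 11 heavy atoms (7 carbon, 3 oxygen, 1 sulfur; one six-membered aromatic ring of carbon only), on a saturated chain carbon bound to an aromatic carbon. Within the data shown here, only the step from compound 2 to compound 3 touches the same part of the molecule, where carboxy gave way to ((trifluoromethyl)sulfonyl)methyl, and it stayed within the scatter. The change to compound 4 goes further, removing the carboxy group and the sulfoxide oxygen at once, so the measured steps give no direct guide; a weakening beyond the scatter is estimated, because compound 2 gives 1100 nM while nothing measured shows what an aminophenyl thioether does here. Compound 4 is expected to give 2500 nM in this assay, between 800 nM and 8000 nM, a step of a 2.3-fold higher number from compound 2 to compound 4 (0.36 log units; beyond the scatter).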

Compound 4, half-maximal inhibitory concentration: 54 nM
The estimate for compound 4 lay 46-fold (1.67 log units) above the measured number; the measured number lies below the stated range.
By their numbers in this assay, from the lowest: compound 4; then compounds 3, 1 and 2 (each within the scatter of the next).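

In this assay, (3-aminophenyl)sulfanyl on the saturated chain carbon bound to an aromatic carbon gives a 20-fold lower number from compound 2 to compound 4 (1.31 log units; beyond the scatter), the only step shown that lies beyond the scatter. This part of the molecule therefore tolerates more than the step from a carboxy group to ((trifluoromethyl)sulfonyl)methyl could show: compound 4 carries neither a carboxy group nor a sulfoxide oxygen and is still the lowest of the four numbers, with its step from compound 2 marked as large. Nothing measured on these compounds explains the size of this step.

The loss of the sulfoxide oxygen, the loss of the carboxy group and the arrival of the amine are joined in this one step, leaving their separate shares unknown. A sulfoxide bearing the 3-aminophenyl group, a thioether bearing a carboxylic acid, or a plain phenyl thioether would pull them apart.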